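Replacing the 4-bromophenyl group of compound 3

The source may report more compounds than this note shows. Statements on the series, on what has been measured and on what is new or still open speak of the compounds shown alone.

In a functional assay on HeLa cells (Homo sapiens) for cytotoxicity, read by MTT assay, with a stated time of 72 h (a lower number here means a stronger inhibitor, a higher number a weaker inhibitor), compound 2 (`O=C(Nc1ccc(Oc2ncnc3[nH]ccc23)c(F)c1)c1cc2cccnc2n(-c2ccc(F)cc2)c1=O`) reads 3720 nM and compound 1 (`Cn1ccc2c(Oc3ccc(NC(=O)c4cc5cccnc5n(-c5ccc(C(F)(F)F)cc5Cl)c4=O)cc3F)ncnc21`) reads 170000 nM at the high end. Compound 3 (`O=C(Nc1ccc(Oc2ncnc3[nH]ccc23)c(F)c1)c1cc2cccnc2n(-c2ccc(Br)cc2)c1=O`) lies between them at 19900 nM as the second highest of the three numbers.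

Compound 4 (`O=C(Nc1ccc(Oc2ncnc3[nH]ccc23)c(F)c1)c1cc2cccnc2n(-c2ccc(C(F)(F)F)cc2Cl)c1=O`) comes from compound 3 by putting 2-chloro-4-(trifluoromethyl)phenyl in place of 4-bromophenyl on an aromatic nitrogen. Within the data shown here, one measured step touches this same aryl group: bromo in place of fluoro on an aromatic carbon (a 5.3-fold higher number from compound 2 to compound 3 (0.73 log units; beyond the scatter)) is modest but beyond the scatter. Compound 4 also lacks the methyl group found on the core of compound 1, which carries the same entering 2-chloro-4-(trifluoromethyl)phenyl and whose 170000 nM serves only as a loose upper guide. Among the measured compounds shown here, no measured step isolates that methyl group. On these two points, a modest rise is expected in this assay for this change (a 2.3-fold higher number from compound 3 to compound 4 (0.35 log units; beyond the scatter)) rather than a large one. In this assay compound 4 is estimated at 45000 nM with an expected range from 12000 nM to 150000 nM overall.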

Compound 4, half-maximal inhibitory concentration: 96800 nM
Compound 4: middle estimate off by 2.2-fold (0.33 log units), on the low side; the range from low to high includes it.
By their numbers in this assay, from the lowest: compound 2; then compound 3; then compounds 4 and 1 (each within the scatter of the next).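

In this assay the aryl group on the aromatic nitrogen gives a second step beyond the scatter, a 4.9-fold higher number from compound 3 to compound 4 (0.69 log units; beyond the scatter), and across the three aryl groups on the shared core the span reaches a 26-fold higher number from compound 2 to compound 4 (1.42 log units; beyond the scatter), so this position can move the number much further than the bromo-for-fluoro step alone had shown. The change on the other aromatic nitrogen of the core behaves differently, with a 1.8-fold lower number from compound 1 to compound 4 (0.24 log units; within the scatter) staying within the scatter, so with 2-chloro-4-(trifluoromethyl)phenyl in place, hydrogen and methyl at that nitrogen cannot be told apart here. No measured information accompanying these compounds offers a reason for either result.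

The chlorine and the trifluoromethyl group enter together, so the compounds shown do not tell how much of the rise belongs to each, nor whether hydrogen and methyl would also read alike with 4-fluorophenyl on the nitrogen. Also open, on these data alone, is how an amine or a carboxylic acid on this phenyl ring would read in this assay, and whether any such group could bring the number below that of compound 2.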